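The compounds below may be only part of what the source reports. "The series", "measured", "known", "first", "only" and "open" are said of these compounds alone.

Measured compounds:
- compound 1 `C=C1[C@@H](OC(C)=O)C[C@@H]2[C@](C)(COC=O)[C@H](OC(C)=O)CC[C@@]2(C)[C@@H]1C[C@@H](Nc1cccc(F)c1)C1=CCOC1=O`: 28600 nM
- compound 2 `C=C1[C@@H](OC(C)=O)C[C@@H]2[C@](C)(CO[Si](C)(C)C(C)(C)C)[C@H](OC(C)=O)CC[C@@]2(C)[C@@H]1C[C@@H](Nc1cccc(F)c1)C1=CCOC1=O`: 4560 nM
- compound 3 `C=C1[C@@H](OC(C)=O)C[C@@H]2[C@](C)(CO[Si](C)(C)C(C)(C)C)[C@H](OC(C)=O)CC[C@@]2(C)[C@@H]1C[C@@H](Nc1ccccc1)C1=CCOC1=O`: 5710 nM

These three were measured in a functional assay on KB cells (Homo sapiens) for cytotoxicity, read by sulforhodamine B assay; a higher number here means a weaker inhibitor, a lower number a stronger inhibitor. Compound 1 gives the highest number of the three, so it is the weakest inhibitor among them; the nearest is compound 3, and compound 2 lies furthest from it. Two single changes connect the set: the step of a 6.3-fold lower number from compound 1 to compound 2 (0.80 log units; beyond the scatter) and the step of a 1.3-fold higher number from compound 2 to compound 3 (0.10 log units; within the scatter).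

Compound 4 `C=C1[C@@H](OC(C)=O)C[C@@H]2[C@](C)(COC=O)[C@H](OC(C)=O)CC[C@@]2(C)[C@@H]1C[C@@H](Nc1ccc(Br)cc1)C1=CCOC1=O` is not yet measured. It differs from compound 1 in one place:

4-bromophenyl in place of 3-fluorophenyl on an amine nitrogen

Within the data shown here, the only measured step that touches this part of the molecule is the one from compound 2 to compound 3, where a hydrogen replaces the fluoro on the aromatic carbon; that step stayed within the scatter. Among the measured compounds shown here, no measured compound carries a bromine, so the effect of the 4-bromophenyl group itself is unknown. For the measured compounds named here, since the one change seen on this ring was small, the expectation for compound 4 is a step of a 1.1-fold lower number from compound 1 to compound 4 (0.06 log units; within the scatter) that does not go beyond the scatter, in either direction. Compound 4 is therefore expected to give about 25000 nM, within a range from 8000 nM to 80000 nM.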

Compound 4, half-maximal inhibitory concentration: 24000 nM
Beside the measured number, compound 4's estimate is 1.0-fold (0.02 log units) above it, and the stated range covers the measured number.
By their numbers in this assay, from the lowest: compounds 2 and 3 (each within the scatter of the next); then compounds 4 and 1 (each within the scatter of the next).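

On the amine nitrogen, 4-bromophenyl in place of 3-fluorophenyl gives a 1.2-fold lower number from compound 1 to compound 4 (0.08 log units; within the scatter) in this assay, so the two compounds cannot be told apart in this assay. This extends the earlier reading, which rested only on a 1.3-fold higher number from compound 2 to compound 3 (0.10 log units; within the scatter) in compounds carrying the larger silicon-containing group: in the formate-bearing pair too, a swap on this aromatic ring does not go beyond the scatter, even though the halogen changes in both identity and ring placement. No measurement at hand explains this flat result.

Because the step changes the halogen and its placement together, the compounds shown leave open what each change does alone, and whether 4-bromophenyl would behave the same way alongside the silicon-containing group of compound 2. Also open, as far as these compounds go, is whether the flat result would hold with a carboxylic acid or an amine on the aromatic ring, or with a saturated chain such as butyl in place of the ring on the amine nitrogen.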